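Series notes: a trifluoromethyl variant of compound 1

The source may hold more compounds than are shown below. What is called first, only, known or untested is meant among the compounds shown, and "the series" means these compounds.

Compound 1 `COc1ccc2ccc(=O)oc2c1C(/C=C/c1ccccc1)=N/NC(N)=O` serves as the reference point. For the measured compounds named here, in a functional assay on HepG2 cells (Homo sapiens) for cytotoxicity, read by MTT assay, with a stated time of 72 h (on this read-out lower numbers stand for stronger inhibition and higher numbers for weaker inhibition), compound 1 gives 82 nM, the highest number among the three measured members. Compound 2 `COc1ccc2ccc(=O)oc2c1C1=NNC(c2ccc(SC)cc2)C1` gives 10 nM and compound 3 `COc1ccc2ccc(=O)oc2c1C1=NN(C(N)=O)C(c2cccs2)C1` gives 26 nM; both gaps from compound 1 lie beyond the scatter, with compound 3 the nearer of the two. Going by the values given here, neither differs from compound 1 in a single place, so no one-point step is available as a guide.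

Compound 4 `COc1ccc2ccc(=O)oc2c1C(/C=C/c1ccc(C(F)(F)F)cc1)=N/NC(N)=O` differs from compound 1 in one place: trifluoromethyl in place of hydrogen on an aromatic carbon. Nothing measured here isolates such a change. The expected step, a 1.4-fold lower number from compound 1 to compound 4 (0.14 log units; within the scatter), is small and may well sit within the scatter, leaning toward a slightly lower number. Compound 4 is estimated at 60 nM, within 20 nM to 180 nM.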

Compound 4, half-maximal inhibitory concentration: 96 nM
For compound 4 the middle estimate is 1.6-fold (0.20 log units) below the measured one, and the stated range covers the measured number.
By their numbers in this assay, from the lowest: compound 2; then compound 3; then compounds 1 and 4 (each within the scatter of the next).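

For the compounds shown here, this is the first one-point step: in this assay, trifluoromethyl in place of hydrogen on an aromatic carbon, para to a large group, gives a 1.2-fold higher number from compound 1 to compound 4 (0.07 log units; within the scatter) and leaves compound 1 and compound 4 indistinguishable on this read-out. Adding these four heavy atoms at this place therefore has no effect that this assay can resolve. No evidence bearing on this result is available.

Going by these compounds, whether an amine or a carboxylic acid at the same place would give a step beyond the scatter remains open. The same question stands for trifluoromethyl on the other carbons of this ring.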